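A Third Chloro on the Aryl Ring of Compound 1

The compounds below may be only part of what the source reports. "The series", "measured", "known", "first", "only" and "open" are said of these compounds alone.

Measured so far:
compound 1, `O=C(NCCO)c1cc(-c2ccc(Cl)cc2Cl)n[nH]1`, 44 nM
compound 2, `O=C(NCCCCO)c1cc(-c2ccc(Cl)cc2Cl)n[nH]1`, 35 nM
compound 3, `CCN(CC)C(=O)c1cc(-c2ccc(Cl)cc2Cl)n[nH]1`, 285 nM

All three were tested in an assay on isolated protein for inhibition of alkaline phosphatase, tissue-nonspecific isozyme (Homo sapiens); on this read-out lower numbers stand for stronger inhibition and higher numbers for weaker inhibition. Compound 1 stands second highest of the three numbers. Its nearest neighbour is compound 2, with a 1.3-fold lower number from compound 1 to compound 2 (0.10 log units; within the scatter). Its furthest is compound 3, with a 6.5-fold higher number from compound 1 to compound 3 (0.81 log units; beyond the scatter); the step of an 8.1-fold higher number from compound 2 to compound 3 (0.91 log units; beyond the scatter) points the same way.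

Compound 4, `O=C(NCCO)c1cc(-c2ccc(Cl)c(Cl)c2Cl)n[nH]1`, has not yet been measured. It differs from compound 1 in one place: chloro in place of hydrogen on an aromatic carbon. None of the three measured steps touches the aryl ring; each of them alters the amide side of the shared core, so they say nothing about what a further chloro on the ring does. Among the compounds with values here, with no step bearing on this change, the expectation for compound 4 is a number close to that of compound 1, with no step expected beyond the scatter, a 1.1-fold lower number from compound 1 to compound 4 (0.04 log units; within the scatter). Compound 4 is therefore estimated at 40 nM, within a range from 15 nM to 120 nM.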

Compound 4, half-maximal inhibitory concentration: 5 nM
Compound 4: the middle estimate sits 8.0-fold (0.90 log units) above what was measured; measured number outside the range, below it.
By their numbers in this assay, from the lowest: compound 4; then compounds 2 and 1 (each within the scatter of the next); then compound 3.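

Within the data shown here, the aryl ring, which none of the earlier steps touched, turns out to be a second place where this assay responds: chloro in place of hydrogen on an aromatic carbon, ortho to two chloro groups and meta to a large group, gives an 8.8-fold lower number from compound 1 to compound 4 (0.94 log units; beyond the scatter). The earlier steps beyond the scatter, all on the amide side, went to higher numbers, so this is the first change shown that goes beyond the scatter towards a lower number. The data shown give no explanation for this effect.

The compounds shown leave open whether fluoro, bromo, methyl or methoxy at this position would give a similar number, or whether the result is particular to chloro. They also leave open whether the same chloro would give a similar step on the diethylamino amide of compound 3 or the 4-hydroxybutyl amide of compound 2.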